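Swapping Pyrrolidine for Imidazole on a Weak Antagonist Scaffold

The compounds below may be only part of what the source reports. "The series", "measured", "known", "first", "only" and "open" are said of these compounds alone.

Compound 1 `CCOC(=O)N(C)C(C)C#CCN1CCCC1` and compound 3 `CC(C#CCN1CCCC1)N1CCN(C)C1=O` share an alkyne chain ending in a pyrrolidin-1-yl group but carry different cores; the difference between the two cores is not broken down here. In a functional assay on the whole organism for antagonist activity, with Mus musculus as the target (a higher number here means that more compound is needed for the effect, a lower number that less compound is needed), compound 3 gives 37 mg/kg. Compound 1 reaches only the limit of this assay, > 100 mg/kg. Compound 2 `CCOC(=O)N(C)C(C)C#CCn1ccnc1` has the same core as compound 1 with the change (1H-imidazol-1-yl in place of pyrrolidin-1-yl on a saturated chain carbon bound to a triple-bonded carbon). Compound 2 also stops at the limit, > 100 mg/kg. This leaves a step that the two limits leave unreadable from compound 1 to compound 2, since (the limit of > 100 mg/kg in this assay, at which 2 of the 3 values shown sit).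

Compound 4 `CC(C#CCn1ccnc1)N1CCN(C)C1=O` applies the same change to compound 3, namely (1H-imidazol-1-yl in place of pyrrolidin-1-yl on a saturated chain carbon bound to a triple-bonded carbon). For the measured compounds named here, no measured step tells how large this change is, so the expectation rests on compound 3 alone, whose value of 37 mg/kg is the only measured number among the three compounds. Compound 4 is therefore expected to need a similar or somewhat larger dose, an estimated step of a 2.2-fold higher number from compound 3 to compound 4 (0.33 log units; beyond the scatter). The estimate for compound 4 is 80 mg/kg, likely between 30 mg/kg and 300 mg/kg.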

Compound 4, dose for half-maximal effect: > 100 mg/kg
Compound 4: only a limit was reported; the forecaster's own chance of this, stated with the estimate: 50%; middle value at least 1.2-fold (0.09 log units) away from the limit.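

In this assay, placing 1H-imidazol-1-yl where pyrrolidin-1-yl stood on the core of compound 3 gives an at least 2.7-fold higher number from compound 3 to compound 4 (0.43 log units; beyond the scatter), so on this core the change means that more compound is needed for the effect. Compound 4 gives > 100 mg/kg, which is a limit of the assay and not a number. The same change on the core of compound 1 gives a step that cannot be read, so the result comes from one core only and does not show whether the change carries over from one core to another: the limit of > 100 mg/kg in this assay, at which 3 of the 4 values shown sit.

The compounds shown leave open whether another group on a saturated chain carbon bound to a triple-bonded carbon, such as piperidin-1-yl or a dimethylamino group, would need less compound than pyrrolidin-1-yl does on the core of compound 3. They also leave open whether such a group would give a readable value on the core of compound 1.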